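From compound 3 to compound 4: one halogen fewer

The source may report more compounds than this note shows. Statements on the series, on what has been measured and on what is new or still open speak of the compounds shown alone.

Of the compounds shown here, three have been measured in a functional assay on NCI-H1975 cells (Homo sapiens) for antiproliferative activity, read by MTT assay, with a stated time of 72 h; a higher number here means a weaker inhibitor, a lower number a stronger inhibitor. Compound 1 `COc1cc2ncnc(Nc3ccc(F)c(Cl)c3)c2cc1OCCCCC(=O)Nc1ccc(S(N)(=O)=O)cc1` gives 35600 nM, compound 2 `COc1cc2ncnc(Nc3ccc(Br)cc3)c2cc1OCCCCC(=O)Nc1ccc(S(N)(=O)=O)cc1` gives 23300 nM, and compound 3 `NS(=O)(=O)c1ccc(NC(=S)Nc2ccc3ncnc(Nc4ccc(F)c(Cl)c4)c3c2)cc1` gives 15800 nM. Compound 3 sits beyond the scatter lower than compound 1, whereas compound 2 lies within the scatter of compound 3, so compound 3 cannot be called the strongest of the set outright.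

Compound 4 `NS(=O)(=O)c1ccc(NC(=S)Nc2ccc3ncnc(Nc4cccc(F)c4)c3c2)cc1` differs from compound 3 in a single place: 3-fluorophenyl in place of 3-chloro-4-fluorophenyl on a nitrogen on an aromatic ring. Among the measured compounds shown here, only one measured step bears on this position, namely a 1.5-fold lower number from compound 1 to compound 2 (0.18 log units; within the scatter), which exchanged the same 3-chloro-4-fluorophenyl group on the other linker and stayed within the scatter. For the measured compounds named here, no measured pair shows the removal of the chlorine alone, and no measured step at all exists on the linker that compound 3 carries, so the evidence is thin and indirect.

On that basis compound 4 is expected to land close to compound 3, with a 1.1-fold higher number from compound 3 to compound 4 (0.06 log units; within the scatter) expected to remain within the scatter. The estimate for compound 4 in this assay is 18000 nM, with a range from 7000 nM to 45000 nM.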

Compound 4, half-maximal inhibitory concentration: 9660 nM
For compound 4 the middle estimate is 1.9-fold (0.27 log units) above the measured one, within the range that was stated.
By their numbers in this assay, from the lowest: compounds 4, 3, 2 and 1 (each within the scatter of the next, the first and the last beyond it).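

In this assay, among the compounds shown here, the step of a 1.6-fold lower number from compound 3 to compound 4 (0.21 log units; within the scatter) is the first measured change at this position on the linker that compound 3 carries, and the first in which the aryl group on a nitrogen on an aromatic ring goes from 3-chloro-4-fluorophenyl to 3-fluorophenyl, keeping one halogen and losing the other. Together with the step of a 1.5-fold lower number from compound 1 to compound 2 (0.18 log units; within the scatter) on the other linker, it gives two exchanges of the 3-chloro-4-fluorophenyl group, and both stay within the scatter, so among these four compounds neither exchange separates the pair it joins. Nothing measured here gives a reason for this result.

Going by these compounds, compounds 1 and 3 differ in more than one place, so the effect of the linker on its own remains unread, and it remains open whether the position would respond the same way on both linkers to one and the same group. On these data alone, it also remains open whether an ethynyl or a methoxy group on the phenyl ring, or a carboxylic acid in place of the sulfonamide, would give a step beyond the scatter.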